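The compounds below may be only part of what the source reports. "The series", "measured", "known", "first", "only" and "open" are said of these compounds alone.

Working notes on the series. The shared core is carried by compound 1 `COc1cc(/C=C/C(=O)c2cccc(-n3cc(-c4ccccc4)[nH]c3=O)c2)ccc1O`, which in a functional assay on NCI-H522 cells (Homo sapiens) for inhibition (a lower number here means a stronger inhibitor of growth, a higher number a weaker inhibitor of growth), gives 2360 nM. Among the measured compounds shown here, compound 2 `O=C(/C=C/c1cccc(O)c1)c1cccc(-n2cc(-c3ccccc3)[nH]c2=O)c1` keeps that core but in this assay compound 2 gives "not determined" (no result reported), so no single number stands for it, and compound 1 is the only anchor with a value. For the measured compounds named here, no step between measured compounds is available here, and what compound 1 and compound 2 together show is one value and one blank.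

Compound 3 `O=C(/C=C/c1cccc(O)c1)c1cccc(-n2cc(-c3ccc(Cl)cc3)[nH]c2=O)c1` differs from compound 2 by chloro in place of hydrogen on an aromatic carbon, para to a large group; cut one bond further out this reads phenyl to 4-chlorophenyl. Going by the values given here, with no measured step for this change, no direction is supported beyond the scatter; a step of modest size in either direction is as likely as none. Among the compounds with values here, compound 3 is expected, on the single anchor of compound 1, to give about 2000 nM in this assay, within a range from 600 nM to 7000 nM.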

Compound 3, concentration for 50% growth inhibition: 1650 nM
Estimate against measurement, compound 3: 1.2-fold (0.08 log units) above; low and high end bracket the measured number.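

Among the compounds shown here, compound 2 has no single number in this assay, so no step from it to compound 3 can be read. No supporting data bear on this result. The compounds shown leave open what phenyl to 4-chlorophenyl does to growth inhibition.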